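The compounds below may be only part of what the source reports. "The series", "measured", "known", "first", "only" and "open" are said of these compounds alone.

Measured so far:
compound 1 `COc1cc(-c2nc(SCc3cn(CC(=O)NC(=O)Nc4ccccn4)nn3)nc(Nc3ccc(C)cc3)c2C#N)cc(OC)c1OC`: 21300 nM
compound 2 `CC(C)c1ccc(Nc2nc(SCc3cn(CC(=O)NC(=O)Nc4ccccn4)nn3)nc(-c3ccc(Cl)cc3)c2C#N)cc1`: > 64000 nM

In a functional assay on ECa-109 cells (Homo sapiens) for inhibition, read by MTT assay, with a stated time of 72 h (a lower number here means a stronger inhibitor, a higher number a weaker inhibitor), compound 1 gives 21300 nM. Compound 2 reaches only a limit of this assay, > 64000 nM, and so carries no number (the limit of > 64000 nM in this assay, at which 1 of the 2 values shown sits). Compound 3 `Cc1ccc(Nc2nc(SCc3cn(CC(=O)NC(=O)Nc4ccccn4)nn3)nc(-c3ccc(Cl)cc3)c2C#N)cc1` differs from compound 2 by methyl in place of isopropyl on an aromatic carbon. Among the compounds with values here, because compound 2 sits at a limit, no measured step guides this change. In this assay the step from compound 2 to compound 3 is expected to be small, at most a modest move toward stronger inhibition, an at least 1.6-fold lower number from compound 2 to compound 3 (0.20 log units; that floor lies within the scatter). Compound 3 is estimated at 40000 nM, between 15000 nM and 120000 nM.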

Compound 3, half-maximal inhibitory concentration: 13100 nM
Estimate against measurement, compound 3: 3.1-fold (0.48 log units) above, outside the stated range (below it).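

In this assay, within the data shown here, the change from (4-isopropylphenyl)amino to (4-methylphenyl)amino gives the first step of readable size at this position: an at least 4.8-fold lower number from compound 2 to compound 3 (0.68 log units; beyond the scatter). Going by these compounds, compound 2 holds only a limit, so the full size of that step stays unknown: the limit of > 64000 nM in this assay, at which 1 of the 3 values shown sits. With 4-chlorophenyl in place of 3,4,5-trimethoxyphenyl, the step is a 1.6-fold lower number from compound 1 to compound 3 (0.21 log units; within the scatter), which does not separate the two groups in this assay.

The compounds shown leave open how an ethyl group, a chlorine atom or a bare hydrogen would read at the position of the methyl. They also leave open whether the isopropyl step would recur with 3,4,5-trimethoxyphenyl on the core.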